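Trimming the Phenoxy Chain Down to Ethyl

The source may report more compounds than this note shows. Statements on the series, on what has been measured and on what is new or still open speak of the compounds shown alone.

Among the compounds with values here, compound 3 `Cc1ccc(-c2cnc(N(CCCCOc3ccccc3)Cc3ccc(C(=O)NO)cc3)s2)cc1` gives 680 nM in a functional assay on HCT-116 cells (Homo sapiens) for antiproliferative activity, read by MTT assay, with a stated time of 48 h (on this read-out higher numbers stand for weaker inhibition of growth and lower numbers for stronger inhibition of growth), the second highest of the three numbers known so far: compound 1 `Cc1ccc(OCCCCN(Cc2ccc(C(=O)NO)cc2)c2ncc(-c3ccc(C)cc3)s2)cc1` gives 580 nM, and compound 2 `CCCN(Cc1ccc(C(=O)NO)cc1)c1ncc(-c2ccc(C)cc2)s1` gives 5800 nM. Compound 4 `CCN(Cc1ccc(C(=O)NO)cc1)c1ncc(-c2ccc(C)cc2)s1` has not yet been measured; it differs from compound 3 by hydrogen in place of 2-phenoxyethyl on a saturated chain carbon, two bonds along the chain from a nitrogen on an aromatic ring. Within the data shown here, two measured steps bear on this change. an 8.5-fold lower number from compound 2 to compound 3 (0.93 log units; beyond the scatter), and a 10-fold higher number from compound 1 to compound 2 (1.00 log units; beyond the scatter). Both steps point the same way, so a step of similar size in the opposite direction is expected here, giving a 10-fold higher number from compound 3 to compound 4 (1.01 log units; beyond the scatter). Compound 4 is therefore expected to give about 7000 nM in this assay, with a range from 3000 nM to 16000 nM.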

Compound 4, concentration for 50% growth inhibition: 6870 nM
Compound 4: the middle estimate sits 1.0-fold (0.01 log units) above what was measured; the measured number falls inside the stated range.
By their numbers in this assay, from the lowest: compounds 1 and 3 (each within the scatter of the next); then compounds 2 and 4 (each within the scatter of the next).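

Trading 4-phenoxybutyl for ethyl gives a 10-fold higher number from compound 3 to compound 4 (1.00 log units; beyond the scatter) in this assay, and the matching change with the methyl on the phenoxy ring gives a 12-fold higher number from compound 1 to compound 4 (1.07 log units; beyond the scatter). Ethyl and propyl, by contrast, read alike, with a 1.2-fold higher number from compound 2 to compound 4 (0.07 log units; within the scatter), so among these compounds the two short chains sit at one level and only the phenoxy-bearing chains give the lower numbers. Nothing available explains this difference.

Still open, as far as these compounds go, is whether a plain hexyl chain, with no phenoxy ring, would match the 4-phenoxybutyl group. An amine or carboxylic acid at the chain end is likewise untested among the compounds shown.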